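The source may hold more compounds than are shown below. What is called first, only, known or untested is meant among the compounds shown, and "the series" means these compounds.

The measured compounds:

compound 1, `CCC(C)Sc1nc(Cc2c(F)cccc2Cl)c(C)c(=O)[nH]1` — > 73000 nM
compound 2, `CCCCSc1nc(Cc2c(F)cccc2Cl)c(C)c(=O)[nH]1` — > 73000 nM
compound 3, `CCC(C)Sc1nc(C(C)c2c(F)cccc2Cl)cc(=O)[nH]1` — > 73000 nM

In an ADME assay on MT4 cells (Homo sapiens) for activation, read by MTT assay (on this read-out lower numbers stand for higher toxicity in this test and higher numbers for lower toxicity in this test), compound 1 reaches only a limit of the test, > 73000 nM. Compound 2 likewise gives only a limit in this assay, > 73000 nM. Compound 3 too gives only a limit in this assay, > 73000 nM. The change from compound 1 to compound 2 is butyl in place of sec-butyl on a sulfur; the step it made, a step that the two limits leave unreadable from compound 1 to compound 2, rests on (the limit of > 73000 nM in this assay, at which 3 of the 3 values shown sit). The difference between the core of compound 1 and the core of compound 3 is not broken down here. Compound 4, `CCCCSc1nc(C(C)c2c(F)cccc2Cl)cc(=O)[nH]1`, carries the same change made on the core of compound 3: butyl in place of sec-butyl on a sulfur. For compound 4 the expected step is a step that the limit leaves unreadable from compound 3 to compound 4, because the same change gave a step that the two limits leave unreadable from compound 1 to compound 2. Compound 4 is therefore estimated at 120000 nM.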

Compound 4, half-maximal cytotoxic concentration: > 73000 nM
Compound 4: a limit, no number; the forecaster's own chance of this, stated with the estimate: 85%; the middle value does not contradict the limit.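

In this assay compound 3 and compound 4 each give only a limit of the test, and no step can be read between them. The compounds shown leave open whether butyl in place of sec-butyl on a sulfur changes toxicity in this assay at all.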